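The source may report more compounds than this note shows. Statements on the series, on what has been measured and on what is new or still open speak of the compounds shown alone.

Measured in an assay on isolated protein for inhibition of Alpha glucosidase (Homo sapiens), read by spectrophotometry, with stated times of 15 min and 30 min; a higher number here means a weaker inhibitor, a lower number a stronger inhibitor:

compound 1, `O=C1NC(=S)S/C1=C\c1ccc(OCN2C(=O)c3ccccc3C2=O)c([N+](=O)[O-])c1`: 6590 nM
compound 2, `O=C1NC(=S)S/C1=C\c1cc(Cl)ccc1OCN1C(=O)c2ccccc2C1=O`: 34800 nM
compound 3, `O=C1NC(=S)S/C1=C\c1cc([N+](=O)[O-])ccc1OCN1C(=O)c2ccccc2C1=O`: 35800 nM

Compound 1 carries the lowest number of the three, and the number of compound 3 is higher than that of compound 1. Compound 1 and compound 3 share the same atoms, joined differently; how their two cores differ is not broken down here. Between compound 3 and compound 2 there is one change, (chloro in place of nitro on an aromatic carbon), and in this assay it made a 1.0-fold lower number from compound 3 to compound 2 (0.01 log units; within the scatter).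

Compound 4, `O=C1NC(=S)S/C1=C\c1ccc(OCN2C(=O)c3ccccc3C2=O)c(Cl)c1`, has not been measured. From compound 1 it differs by chloro in place of nitro on an aromatic carbon. This is the same kind of change as that from compound 3 to compound 2, but the surroundings are not identical: in compound 2 the chloro is meta to a group of 8 heavy atoms and para to a large group, while in compound 4 it is ortho to a large group and meta to a group of 8 heavy atoms. Resting on the flat step measured for compound 3 to compound 2, a 1.0-fold lower number from compound 3 to compound 2 (0.01 log units; within the scatter), the step in this assay is expected to be a 1.1-fold higher number from compound 1 to compound 4 (0.06 log units; within the scatter). Compound 4 is therefore estimated at 7500 nM, with a range from 3000 nM to 20000 nM.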

Compound 4, half-maximal inhibitory concentration: 5440 nM
Estimate against measurement, compound 4: 1.4-fold (0.14 log units) above, and the stated range covers the measured number.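

In this assay, chloro in place of nitro on the core of compound 1 gave a 1.2-fold lower number from compound 1 to compound 4 (0.08 log units; within the scatter), and this step matches the earlier one: the same change on two cores in this assay, a 1.0-fold lower number (0.01 log units; within the scatter) from compound 3 to compound 2 and a 1.2-fold lower number (0.08 log units; within the scatter) from compound 1 to compound 4, 1.2-fold (0.07 log units) apart, within the scatter of two such steps

On these two cores, then, the exchange carried over, leaving the number unmoved within the scatter on both, so the measured step on one core would have served as a fair guide to the other. Among the compounds shown here, this rests on only two pairs and a single change, however, and it shows neither that the result extends to other cores nor what sets the cores themselves apart.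

Going by these compounds, it remains open whether other groups on the same aromatic carbon, such as a methoxy group, an amine or a carboxylic acid, would leave the number just as flat. The compounds shown also leave open what a longer chain in place of the link between the aromatic ring and the large group would do.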